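The source may hold more compounds than are shown below. What is called first, only, known or untested is meant among the compounds shown, and "the series" means these compounds.

Working notes on the series. The shared core is carried by compound 1 `Nc1cc(N)c2nc(-c3ccccc3)c(Oc3ccc(Cl)c(Cl)c3)nc2c1`, compound 2 `Nc1cc(N)c2nc(-c3ccccc3)c(NCc3ccc(F)cc3)nc2c1` and compound 3 `COc1ccc(Sc2nc3cc(N)cc(N)c3nc2-c2ccccc2)cc1`. In a functional assay on K562 cells (Homo sapiens) for inhibition, read by sulforhodamine B assay, with a stated time of 48 h (a higher number here means that more compound is tolerated, a lower number that less compound is tolerated), compound 1 gives < 100000 nM, which is a limit of the assay and not a number. In this assay compound 2 likewise reaches only the limit < 100000 nM. In this assay compound 3 also stands at the limit < 100000 nM. On the numbers shown compound 3 therefore cannot be placed against the other two: the limit of < 100000 nM in this assay, at which 3 of the 3 values shown sit, so the steps a step that the two limits leave unreadable from compound 1 to compound 2, a step that the two limits leave unreadable from compound 1 to compound 3 and a step that the two limits leave unreadable from compound 2 to compound 3 have no readable size.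

Compound 4 `Nc1cc(N)c2nc(-c3ccccc3)c(Sc3ccc(Cl)c(Cl)c3)nc2c1` is not yet measured. It differs from compound 3 by 3,4-dichlorophenyl in place of 4-methoxyphenyl on a sulfur. Going by the values given here, none of the measured steps concerns an exchange on the sulfur, and the steps that exist are unreadable, so neither a direction nor a size can be taken from them. In this assay compound 4 is therefore expected near 30000 nM, within 5000 nM to 100000 nM, the step from compound 3 being estimated as a step that the limit leaves unreadable from compound 3 to compound 4, with a fair chance that again only the limit is reported.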

Compound 4, concentration lethal to 50% of the cells: < 100000 nM
Compound 4 gave a limit, no number; the forecaster's own chance of this, stated with the estimate: 60%; the middle value is on the limit's open side.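

Compound 4 adds no readable step: its steps from compound 1, compound 2 and compound 3 stay unreadable, as every value shown is a limit and not a number: the limit of < 100000 nM in this assay, at which 4 of the 4 values shown sit. In this assay the compounds shown leave open whether any of these exchanges changes the read-out, and in which direction.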